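The source may hold more compounds than are shown below. What is called first, only, known or untested is meant among the compounds shown, and "the series" means these compounds.

Measured compounds:

Compound 1 `O=C(Nc1cccc(-n2cc(-c3ccncc3)c(-c3cc(O)cc(Cl)c3)n2)c1)Nc1ccc(Cl)c(C(F)(F)F)c1`; in a functional assay on NCI-H23 cells (Homo sapiens) for inhibition, read by sulforhodamine B assay, with a stated time of 48 h, tested at 0.01 uM (on this read-out lower numbers stand for a stronger effect and higher numbers for a weaker effect at the one concentration tested), compound 1 gives 92%.

Compound 2 `O=C(Nc1cccc(-n2cc(-c3ccncc3)c(-c3cc(O)cc(Cl)c3)n2)c1)Nc1ccc(Cl)c(Cl)c1`; in this assay compound 2 gives 96%.

Compound 1 stands at the lowest of the two numbers in this assay, but its nearest neighbour is compound 2, and the step of a number 4 percentage points higher from compound 1 to compound 2 (within the scatter) lies within the scatter, so the two values cannot be told apart on this read-out. Compound 3 `COc1cc(Cl)cc(-c2nn(-c3cccc(NC(=O)Nc4ccc(Cl)c(C(F)(F)F)c4)c3)cc2-c2ccncc2)c1` has not yet been measured. It differs from compound 1 in one place: methyl in place of hydrogen on an oxygen on an aromatic ring. For the measured compounds named here, no measured step touches this oxygen. Going by the values given here, the only step available, a number 4 percentage points higher from compound 1 to compound 2 (within the scatter), concerns the aryl urea end of the molecule and did not move the number beyond the scatter, so it gives no direct guidance for the change at the phenol. With nothing in the data pointing either way, no step beyond the scatter is expected in this assay in either direction. Compound 3 is therefore estimated to give 93%, with a range from 82% to 102%. The step this estimate implies, a number 1 percentage points higher from compound 1 to compound 3 (within the scatter), is expected to stay within the scatter.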

Compound 3, a percentage reported as activity, at one concentration (the size of the read-out at that concentration, not a potency): 90%
The estimate for compound 3 lay 3 percentage points above the measured number, and the stated range covers the measured number.
By their numbers in this assay, from the lowest: compounds 3, 1 and 2 (each within the scatter of the next).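

In this assay, for the compounds shown here, the change from hydroxy to methoxy on the 3-chloro-5-hydroxyphenyl group gives a number 2 percentage points lower from compound 1 to compound 3 (within the scatter), so the first measured change at this oxygen yields a number that cannot be told apart from that of compound 1. The hydrogen on this oxygen can therefore be replaced by methyl without a step beyond the scatter at the one concentration tested, and the same holds for the chloro-for-trifluoromethyl change at the aryl urea end, a number 4 percentage points higher from compound 1 to compound 2 (within the scatter). Nothing available explains this result, and the data give no basis for assigning a role to the hydroxy hydrogen.

From the compounds shown here alone, whether a larger group on this oxygen, such as an ethyl or a longer chain ending in an amine or a carboxylic acid, would move the number beyond the scatter remains open. Also open, going by these compounds, is whether replacing the whole hydroxy group with an amine would do so, and whether any of these differences would appear in this assay as a step beyond the scatter.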